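This account rests on a few compounds, and the source may have more. Where it says the series, first, only, none or still open, it means among the compounds named here.

Measured in an assay for binding affinity to dual specificity mitogen-activated protein kinase kinase 4 (Homo sapiens), read by KINOMEscan, tested at 100 nM; on this read-out lower numbers stand for a stronger effect and higher numbers for a weaker effect at the one concentration tested:
- compound 1, `CCCS(=O)(=O)Nc1ccc(F)c(C(=O)c2n[nH]c3ncc(-c4ccccc4Cl)cc23)c1F`: 9.3%
- compound 2, `CCCS(=O)(=O)Nc1ccc(F)c(C(=O)c2n[nH]c3ncc(-c4cccc(C(F)(F)F)c4)cc23)c1F`: 57%
- compound 3, `CCCS(=O)(=O)Nc1ccc(F)c(C(=O)c2n[nH]c3ncc(-c4ccc(C(F)(F)F)cc4)cc23)c1F`: 29%

Compound 3 stands second highest of the three numbers in this assay; its nearest neighbour is compound 1, the step of a number 19.7 percentage points higher from compound 1 to compound 3 (beyond the scatter) being beyond the scatter, and its furthest is compound 2, with a number 28 percentage points lower from compound 2 to compound 3 (beyond the scatter) also beyond the scatter. The largest movement in the series is a number 47.7 percentage points higher from compound 1 to compound 2 (beyond the scatter).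

The next step leads to compound 4, `CCCS(=O)(=O)Nc1ccc(F)c(C(=O)c2n[nH]c3ncc(-c4ccc(C(=O)O)cc4)cc23)c1F`, which differs from compound 3 as follows: carboxy in place of trifluoromethyl on an aromatic carbon. Going by the values given here, none of the measured steps changes the trifluoromethyl itself; all three only move or exchange the substituent on the pendant phenyl, and those exchanges shifted the read-out in this assay by modest to large amounts. Among the compounds with values here, compound 4 therefore has no direct precedent, and the expectation can only be that a change of substituent of this kind moves the number beyond the scatter, with the direction open. Weighing the spread of the three measured values, the step of a number 16 percentage points higher from compound 3 to compound 4 (beyond the scatter) is taken as the expected outcome, and compound 4 is estimated at 45% in this assay, within 15% to 85%.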

Compound 4, a percentage reported as activity, at one concentration (the size of the read-out at that concentration, not a potency): 0.1%
Compound 4: middle estimate off by 44.9 percentage points, on the high side; measured number outside the range, below it.
By their numbers in this assay, from the lowest: compounds 4 and 1 (each within the scatter of the next); then compound 3; then compound 2.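

In this assay, going by these compounds alone, with the place held fixed, para to a large group, carboxy in place of trifluoromethyl gives a number 28.9 percentage points lower from compound 3 to compound 4 (beyond the scatter) and so shows that the substituent alone moves the number, whereas the earlier steps also changed where it sat or what else the phenyl carried. Within the data shown here, a 4-substituted phenyl is therefore no bar to a low number: a number 9.2 percentage points lower from compound 1 to compound 4 (within the scatter) is the only step that stays within the scatter, while a number 56.9 percentage points lower from compound 2 to compound 4 (beyond the scatter) marks how far the pendant phenyl alone can carry the read-out. Nothing available explains this change.

Going by these compounds, whether the low number belongs to carboxy itself remains open, and a methyl ester or a primary amide at the same place would address that. Also open, on these data alone, is whether a 3-carboxyphenyl or 2-carboxyphenyl would behave like the 4-carboxyphenyl.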